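This account rests on a few compounds, and the source may have more. Where it says the series, first, only, none or still open, it means among the compounds named here.

Of the compounds shown here, two sharing one core have so far been measured in a functional assay on SMMC-7721 cells (Homo sapiens) for cytotoxicity, read by MTT assay, with a stated time of 72 h; on this read-out higher numbers stand for weaker inhibition and lower numbers for stronger inhibition. Compound 1 `O=C1C(=Cc2ccc(Cl)cc2)C(=O)N(c2ccc(Cl)cc2)N1c1ccc(Cl)cc1` gives 30900 nM in this assay, the lowest of the two numbers. Compound 2 `COc1cc(C=C2C(=O)N(c3ccc(Cl)cc3)N(c3ccc(Cl)cc3)C2=O)ccc1O` carries 4-hydroxy-3-methoxyphenyl in place of 4-chlorophenyl on a double-bonded chain carbon bound to a double-bonded ring carbon, and gives 64900 nM in this assay. That change, a 2.1-fold higher number from compound 1 to compound 2 (0.32 log units; beyond the scatter), shows that swapping the ring at this position moves the number only modestly.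

Compound 3 `O=C1C(=Cc2ccccc2)C(=O)N(c2ccc(Cl)cc2)N1c1ccc(Cl)cc1` differs from compound 1 by hydrogen in place of chloro on an aromatic carbon, which, cut one bond further out, reads 4-chlorophenyl to phenyl. Among the measured compounds shown here, the only measured step touching the same ring is the one from compound 1 to compound 2, and it was modest, so no large shift is expected here either. The number for compound 3 in this assay is estimated at 45000 nM, within 18000 nM to 110000 nM, which would mean an expected step of a 1.5-fold higher number from compound 1 to compound 3 (0.16 log units; within the scatter).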

Compound 3, half-maximal inhibitory concentration: 26200 nM
Beside the measured number, compound 3's estimate is 1.7-fold (0.23 log units) above it; low and high end bracket the measured number.
By their numbers in this assay, from the lowest: compounds 3 and 1 (each within the scatter of the next); then compound 2.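

In this assay, hydrogen in place of chloro gives a 1.2-fold lower number from compound 1 to compound 3 (0.07 log units; within the scatter), so the chloro on this ring can go without any change that stands clear of the scatter. The comparison with the substituted ring gives a 2.5-fold lower number from compound 2 to compound 3 (0.39 log units; beyond the scatter), a modest step beyond the scatter, which shows that plain phenyl and 4-chlorophenyl both stand apart from 4-hydroxy-3-methoxyphenyl. Compound 2 differs from compound 3 by both a hydroxy and a methoxy group, so these numbers cannot show which of the two matters, or whether both do.

Still open, from the compounds shown here alone, is whether an amine or a carboxylic acid on this ring would move the number further, and what changing the two 4-chlorophenyl groups on the shared core would do. No measurement here offers a reason for these differences.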